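The source may report more compounds than this note shows. Statements on the series, on what has been measured and on what is new or still open speak of the compounds shown alone.

Compound 1 `c1ccc(-c2cn3ccnc3c(-c3ccc4ncn(C5CCCCC5)c4c3)n2)cc1`: 92%
Compound 2 `c1csc(-c2cn3ccnc3c(-c3ccc4ncn(C5CCCCC5)c4c3)n2)c1`: 49.1%

Compound 3 is `FC(F)(F)c1cccc(-c2cn3ccnc3c(-c3ccc4ncn(C5CCCCC5)c4c3)n2)c1`, not yet measured in a functional assay on PC-3 cells (Homo sapiens) for inhibition, read by sulforhodamine B assay, with a stated time of 48 h, tested at 10 uM; a lower number here means less inhibition, a higher number more inhibition at the concentration tested (going by the name of the read-out). Among the two numbers seen, compound 2 stands lowest, with compound 1 as its only neighbour at 92%, a gap beyond the scatter. The change is 3-(trifluoromethyl)phenyl in place of thiophen-2-yl on an aromatic carbon. Among the measured compounds shown here, the single measured step that bears on it is the reverse exchange, a number 42.9 percentage points lower from compound 1 to compound 2 (beyond the scatter), which ran from phenyl to thiophen-2-yl and lost much inhibition. Compound 3 restores a six-membered ring of carbon only, now carrying a trifluoromethyl group, so the expectation is a step back up toward compound 1 and its 92%. For the measured compounds named here, no measured step tells what the trifluoromethyl group itself contributes, which widens the range. The estimate for compound 3 is 80% with a range of 55% to 98%, meaning an expected step of a number 30.9 percentage points higher from compound 2 to compound 3 (beyond the scatter).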

Compound 3, a percentage reported as inhibition, at one concentration (the size of the read-out at that concentration, not a potency): 36.5%
For compound 3 the middle estimate is 43.5 percentage points above the measured one; the whole stated range lies above it.
By their numbers in this assay, from the lowest: compound 3; then compound 2; then compound 1.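

On this aromatic carbon, a trifluoromethyl group on the phenyl ring gives a number 55.5 percentage points lower from compound 1 to compound 3 (beyond the scatter) in this assay and so marks substitution of that ring as a sensitive change. A six-membered aromatic ring of carbon only does not by itself secure inhibition, as 3-(trifluoromethyl)phenyl in place of thiophen-2-yl gives a number 12.6 percentage points lower from compound 2 to compound 3 (beyond the scatter) in this assay and leaves unsubstituted phenyl as the only group shown with high inhibition. No measurement at hand accounts for these losses.

Still open, from the compounds shown here alone, is whether the loss follows trifluoromethyl in particular or any group on the phenyl ring, which a fluorine, a methoxy group or an amine there would help to separate. Also open, going by these compounds, is how a pyridine ring or a saturated cyclohexyl group would read at this carbon.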